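From Chlorophenyl to Hydroxyphenyl: One Step Weighed

This account rests on a few compounds, and the source may have more. Where it says the series, first, only, none or still open, it means among the compounds named here.

Of the compounds shown here, two sharing one core have been tested in a functional assay on HT29-AK cells (Homo sapiens) for cytotoxicity, read by MTT assay, with a stated time of 48 h; on this read-out lower numbers stand for stronger inhibition and higher numbers for weaker inhibition. Compound 1 `Fc1cccc(-c2nc(Nc3ccccc3)c3ccccc3n2)c1` returned only a limit of the assay, > 50000 nM. That result is the limit of > 50000 nM in this assay, at which 1 of the 2 values shown sits. Within the data shown here, compound 2 `Fc1cccc(-c2nc(Nc3ccc(Cl)cc3)c3cc(F)ccc3n2)c1` gave 40300 nM in this assay, the sole numeric value among the two, so it stands as the only compound with a measured half-maximal inhibitory concentration here. Compound 3 `Oc1ccccc1Nc1nc(-c2cccc(F)c2)nc2ccc(F)cc12` differs from compound 2 in one place: 2-hydroxyphenyl in place of 4-chlorophenyl on a nitrogen on an aromatic ring. Among the measured compounds shown here, no measured pair in this set isolates the effect of that change, so the expectation rests on the weak activity of compound 2 alone. The step of a 1.1-fold higher number from compound 2 to compound 3 (0.05 log units; within the scatter) is expected to be small, likely none beyond the scatter, with a real chance that the assay returns only a limit again. For compound 3 the half-maximal inhibitory concentration in this assay is estimated at 45000 nM, within a range from 15000 nM to 150000 nM.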

Compound 3, half-maximal inhibitory concentration: > 50000 nM
Compound 3 gave a limit, no number; the forecaster's own chance of this, stated with the estimate: 40%; middle value at least 1.1-fold (0.04 log units) away from the limit.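

In this assay the change to 2-hydroxyphenyl in place of 4-chlorophenyl on a nitrogen on an aromatic ring reads as an at least 1.2-fold higher number from compound 2 to compound 3 (0.09 log units; that floor lies within the scatter), so this exchange shows no gain at this position. The step gives only a floor, and the true distance between the two compounds remains unread. Compound 3 joins compound 1 at the limit, which now accounts for most of the set: the limit of > 50000 nM in this assay, at which 2 of the 3 values shown sit.

The compounds shown leave open how far compound 3 lies from compound 2, as a limit gives no size for that distance. They also leave open whether a phenyl ring carrying an amine or a carboxylic acid on that same nitrogen would return a lower number in this assay than compound 2 does.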